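Aryl Amine Restored: From Cyclopropyl Back to Methoxyphenyl

This account rests on a few compounds, and the source may have more. Where it says the series, first, only, none or still open, it means among the compounds named here.

Of the compounds shown here, three with a shared core have been measured in a functional assay on MCF7 cells (Homo sapiens) for inhibition, read by sulforhodamine B assay; a higher number here means a weaker inhibitor, a lower number a stronger inhibitor. Compound 1 `COc1cccc(NC2=CC(=O)c3c(nc4n3[C@H]3OC[C@@H](O)[C@H]3OC4)C2=O)c1` carries a 3-methoxyphenyl group on the amine nitrogen and gives 3830 nM. Compound 2 `O=C1C(Nc2cccc(Cl)c2)=CC(=O)c2c1nc1n2[C@H]2OC[C@@H](O)[C@H]2OC1` carries a 3-chlorophenyl group there and gives 2970 nM; the change is a 1.3-fold lower number from compound 1 to compound 2 (0.11 log units; within the scatter). Compound 3 `O=C1C(NC2CC2)=CC(=O)c2c1nc1n2[C@H]2OC[C@@H](O)[C@H]2OC1`, with a cyclopropyl group on the amine nitrogen, reaches only a limit of the assay, > 16000 nM, so compound 3 stands at the limit of > 16000 nM in this assay, at which 1 of the 3 values shown sits, rather than at a number.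

Compound 4 `COc1ccc(NC2=CC(=O)c3c(nc4n3[C@H]3OC[C@@H](O)[C@H]3OC4)C2=O)cc1` differs from compound 3 by 4-methoxyphenyl in place of cyclopropyl on an amine nitrogen. Among the measured compounds shown here, two measured steps bear on this change, both running in the opposite direction: an at least 4.1-fold higher number from compound 1 to compound 3 (0.62 log units; beyond the scatter) and an at least 5.3-fold higher number from compound 2 to compound 3 (0.73 log units; beyond the scatter). Putting an aryl group back on the amine nitrogen should therefore reverse that loss, and compound 4 is expected to land near compound 1, since its 4-methoxyphenyl group differs from the 3-methoxyphenyl of compound 1 only in where the methoxy sits.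

Compound 4 is thus estimated at 4000 nM, within 1500 nM to 12000 nM. The expected step is an at least 4.0-fold lower number from compound 3 to compound 4 (0.60 log units; beyond the scatter).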

Compound 4, half-maximal inhibitory concentration: 4470 nM
Beside the measured number, compound 4's estimate is 1.1-fold (0.05 log units) below it; low and high end bracket the measured number.
By their numbers in this assay, from the lowest: compounds 2, 1 and 4 (each within the scatter of the next). At a limit, above all of these: compound 3.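

In this assay, the 4-methoxyphenyl group on the amine nitrogen gives the gain over cyclopropyl as a forward step, an at least 3.5-fold lower number from compound 3 to compound 4 (0.55 log units; beyond the scatter), so the loss seen with cyclopropyl now has a third aryl group set against it. Where the methoxy sits does not separate the two methoxyphenyl compounds, a 1.2-fold higher number from compound 1 to compound 4 (0.07 log units; within the scatter), and exchanging 3-chlorophenyl for 4-methoxyphenyl also stays within the scatter, a 1.5-fold higher number from compound 2 to compound 4 (0.18 log units; within the scatter), so the three aryl groups cannot be told apart here. The value of compound 3 remains a limit and not a number, so the true size of the step from cyclopropyl stays unknown: the limit of > 16000 nM in this assay, at which 1 of the 4 values shown sits.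

The compounds shown leave open whether a longer alkyl chain or a benzyl group on this nitrogen would behave like cyclopropyl or like the aryl groups. They also leave open what an unsubstituted phenyl ring, or a carboxylic acid on the ring, would do.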